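Cyclic ether in place of a flexible chain on aminoquinoline

The source may report more compounds than this note shows. Statements on the series, on what has been measured and on what is new or still open speak of the compounds shown alone.

The series shares one core, carrying an amine and an aryl ether side chain. Compound 1 `CC1CCC(Oc2cccc3ccc(N)nc23)C1` bears a methylcyclopentyl group on that oxygen and in an assay on cells with melanin-concentrating hormone receptor 1 (Homo sapiens) as the target, read by radioligand binding (on this read-out higher numbers stand for weaker inhibition and lower numbers for stronger inhibition), compound 1 gives 823 nM. Compound 2 `COCCOCCOc1cccc2ccc(N)nc12` carries a (2-methoxyethoxy)methyl chain instead, and in this assay compound 2 gives > 2000 nM, which is a limit of the assay rather than a number, as noted in the limit of > 2000 nM in this assay, at which 1 of the 2 values shown sits. Compound 2 therefore stands at the weak end of what is shown, without a figure of its own.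

Compound 3 `Nc1ccc2cccc(OCC3CCCO3)c2n1` differs from compound 2 by oxolan-2-yl in place of (2-methoxyethoxy)methyl on a saturated chain carbon bound to an oxygen on an aromatic ring. Within the data shown here, no measured step between neighbouring compounds is available to calibrate this change, so the expectation rests on the two values shown and on the size of the change itself. A modest move toward stronger inhibition is expected, the step of an at least 1.3-fold lower number from compound 2 to compound 3 (0.12 log units; that floor lies within the scatter) being estimated as small and uncertain because compound 2 is known only as the limit > 2000 nM. Compound 3 is expected to give about 1500 nM, within 500 nM to 5000 nM.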

Compound 3, half-maximal inhibitory concentration: > 2000 nM
Compound 3 gave a limit, no number; the forecaster's own chance of this, stated with the estimate: 40%; at least 1.3-fold (0.12 log units) between middle value and limit.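

In this assay compound 3 gives > 2000 nM, which is again a limit of the assay and not a number, so the oxolan-2-yl group on a saturated chain carbon bound to an oxygen on an aromatic ring does not bring a readable value where the (2-methoxyethoxy)methyl chain gave none. The step between compound 2 and compound 3 cannot be read, and the series now gathers at one end of the read-out: the limit of > 2000 nM in this assay, at which 2 of the 3 values shown sit. Among these compounds, the one step that can be read is an at least 2.4-fold higher number from compound 1 to compound 3 (0.38 log units; beyond the scatter), with (oxolan-2-yl)methyl in place of 3-methylcyclopentyl on an oxygen on an aromatic ring, which shows that a ring in this side chain is not enough in itself to match compound 1.

Going by these compounds, how far compound 2 and compound 3 lie beyond their shared limit stays open, and with it whether the ring or the open chain is the better of the two. Also open, on these data alone, is what a plain cyclopentyl group, or a chain ending in an amine, would give on this oxygen compared with compound 1.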